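Trimming the aryl amide of compound 1 to an acetamide

The source may hold more compounds than are shown below. What is called first, only, known or untested is meant among the compounds shown, and "the series" means these compounds.

Of the compounds shown here, three share one core and have been tested in a functional assay on HepG2 cells (Homo sapiens) for cytotoxicity, read by MTT assay, with a stated time of 48 h; on this read-out lower numbers stand for stronger inhibition and higher numbers for weaker inhibition. Compound 1 `COc1ccc(CNC(=O)CSc2nc3ccc(NC(=O)c4ccc(Cl)cc4)cc3s2)cc1` gives 7400 nM, the lowest of the three numbers. Compound 2 `O=C(CSc1nc2ccc(NC(=O)c3ccc(Cl)cc3)cc2s1)NCc1ccc(Cl)cc1` gives 17800 nM, and the change from compound 1 to compound 2, chloro in place of methoxy on an aromatic carbon, brings a 2.4-fold higher number from compound 1 to compound 2 (0.38 log units; beyond the scatter). Compound 3 `CNC(=O)CSc1nc2ccc(NC(=O)c3ccccc3)cc2s1` gives 26500 nM, the highest number of the set.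

Compound 4 `COc1ccc(CNC(=O)CSc2nc3ccc(NC(C)=O)cc3s2)cc1` has not yet been measured. It differs from compound 1 by methyl in place of 4-chlorophenyl on a carbonyl carbon. Among the measured compounds shown here, no measured step touches this position: the only step in hand, a 2.4-fold higher number from compound 1 to compound 2 (0.38 log units; beyond the scatter), sits on the other end of the molecule, and compound 3 differs from compound 1 in two places at once, so its value shows nothing on this change alone. With a whole aromatic ring removed from the amide, a weaker result than compound 1 is expected, so the number for compound 4 is estimated at 22000 nM, within a range from 7000 nM to 70000 nM, meaning an expected step of a 3.0-fold higher number from compound 1 to compound 4 (0.47 log units; beyond the scatter).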

Compound 4, half-maximal inhibitory concentration: 11200 nM
For compound 4 the middle estimate is 2.0-fold (0.29 log units) above the measured one, within the range that was stated.
By their numbers in this assay, from the lowest: compounds 1, 4, 2 and 3 (each within the scatter of the next, the first and the last beyond it).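

In this assay, methyl in place of 4-chlorophenyl on a carbonyl carbon gives a 1.5-fold higher number from compound 1 to compound 4 (0.18 log units; within the scatter), so this first measured change at the position leaves the two compounds indistinguishable. Acetamido can therefore stand in for ((4-chlorophenyl)carbonyl)amino on the core of compound 1 without a step beyond the scatter, which means this aromatic ring is not required to reach this level of cytotoxicity in these cells. Nothing available explains why the loss of the ring makes so little difference.

Still open, as far as these compounds go, is whether a longer chain such as propyl, or an amine-bearing group such as aminomethyl, on this carbonyl carbon would shift the number beyond the scatter. It is also unknown whether acetamido would behave the same way on the core of compound 2, with its chloro group in place of methoxy.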